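A few compounds are considered here, and "the series" means these few. Any claim that something is new, unique, unknown or untested is made for them only; others in the source may bear on it.

Compound 3 `CSCC[C@H](NC(=O)c1ccc(CNCc2[nH]cnc2C)cc1-c1ccccc1C)C(=O)O` has been tested in a functional assay on NIH3T3 cells (Mus musculus); a higher number here means that more compound is needed for the effect, a lower number that less compound is needed. In this assay compound 3 gives > 10 uM, which is a limit of the assay and not a number. Two related compounds stand at the same point. Compound 1 `COC(=O)[C@H](CCSC)NC(=O)c1ccc(NCc2cncn2Cc2ccc(C#N)cc2)cc1-c1ccccc1` gives > 10 uM, also a limit. Compound 2 `COC(=O)[C@H](CCSC)NC(=O)c1ccc(NCc2cncn2Cc2ccc(-c3ccccc3)cc2)cc1-c1ccccc1` gives > 10 uM, again a limit. Among the measured compounds shown here, the step that the two limits leave unreadable from compound 1 to compound 2 therefore cannot be sized because the limit of > 10 uM in this assay, at which 3 of the 3 values shown sit, is where every value so far sits.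

Compound 4 `CSCC[C@H](NC(=O)c1ccc(CNCc2c[nH]cn2)cc1-c1ccccc1C)C(=O)O` is the next compound in the series and has not yet been measured in this assay. It differs from compound 3 in one place: 1H-imidazol-4-yl in place of 4-methyl-1H-imidazol-5-yl on a saturated chain carbon bound to an amine nitrogen. For the measured compounds named here, none of the measured steps bears on this change, since the only measured step is unreadable and the remaining compounds supply limits alone. With compound 3 at a limit, there is no number from which a direction could be taken.

Compound 4 is therefore expected to give about 15 uM in this assay, within a range of 3 uM to 60 uM. The step that the limit leaves unreadable from compound 3 to compound 4 that this estimate means is expected to stay within the usual scatter, with a sizeable chance that the assay again reports only a limit.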

Compound 4, concentration for half-maximal effect: > 25 uM
Compound 4: no number, only a limit (the forecaster's own chance of this, stated with the estimate: 65%); middle value at least 1.6-fold (0.22 log units) from the limit.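

In this assay compound 4 gives > 25 uM, which is a limit of the assay and not a number. Compound 3 also stands at a limit, so no step can be read between compound 3 and compound 4. The compounds shown leave open what actual number any of them would give in this assay, and so how any single change alters it.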